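A few compounds are considered here, and "the series" means these few. Any claim that something is new, unique, unknown or untested is made for them only; others in the source may bear on it.

Of the compounds shown here, three have so far been tested in a functional assay on NCI-H460 cells (Homo sapiens) for antiproliferative activity; on this read-out lower numbers stand for stronger inhibition of growth and higher numbers for weaker inhibition of growth. Compound 1 `Cc1cc(C)c2c(O)cc(-c3cccc4ccccc34)nc2n1` gives 631 nM, compound 2 `Cc1cccc(-c2cc(O)c3cc(C)cnc3n2)c1` gives 389 nM, and compound 3 `Cc1cnc2[nH]c(-c3cccc(F)c3)cc(=O)c2c1` gives 38.9 nM. Compound 3 therefore shows the lowest number of the three; its nearest neighbour is compound 2, and both that gap and the larger one to compound 1 lie beyond the scatter of repeated measurement, so compound 3 is the most potent of the set.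

Compound 4 `Cc1cnc2[nH]c(-c3cccc(Cl)c3)cc(=O)c2c1` has not yet been measured. It differs from compound 3 in a single place: chloro in place of fluoro on an aromatic carbon. The change exchanges one heavy atom for another on the six-membered aromatic ring of carbon only, meta to a large group. Within the data shown here, no measured pair shows this exact exchange, so there is no earlier step to lean on. For compound 4 a step that stays within the scatter is expected, perhaps with a slight lowering, as a 1.3-fold lower number from compound 3 to compound 4 (0.11 log units; within the scatter). In this assay compound 4 is accordingly expected to give about 30 nM, likely between 12 nM and 90 nM.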

Compound 4, concentration for 50% growth inhibition: 50.1 nM
For compound 4 the middle estimate is 1.7-fold (0.22 log units) below the measured one; measured number inside the range.
By their numbers in this assay, from the lowest: compounds 3 and 4 (each within the scatter of the next); then compounds 2 and 1 (each within the scatter of the next).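

In this assay, among these compounds, putting chloro in place of fluoro on this six-membered aromatic ring of carbon only gives a 1.3-fold higher number from compound 3 to compound 4 (0.11 log units; within the scatter), the first direct reading of a change at this position. With the rest of the molecule held constant, the two halogen atoms cannot be told apart on this read-out, so this position accepts either one without a change beyond the usual scatter of repeated measurements. No measured information offers an explanation for this result.

On these data alone, only these two single-atom groups are compared here, so it remains open how the same position would respond to a larger or very different group, such as a methoxy group, an amine or a carboxylic acid. Also open, as far as these compounds go, is whether chloro and fluoro would remain equivalent at another place on the ring.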